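The compounds below may be only part of what the source reports. "The series", "measured", "known", "first", "only" and "open" are said of these compounds alone.

Compound 2 `CCOC(=O)c1ccc(SCc2ccc3nc(OC)c(OC)nc3c2)nc1` and compound 1 `COc1nc2ccc(CSc3ccccn3)cc2nc1OC` share one core and differ only at one aromatic carbon. In an ADME assay on Vero 76 cells (Chlorocebus sabaeus) for cytotoxicity, read by MTT assay, with a stated time of 96 h (a lower number here means that less compound is tolerated, a higher number that more compound is tolerated), compound 2 gives > 100000 nM, which is a limit of the assay rather than a measured number. Compound 1 in this assay likewise gives > 100000 nM, again a limit. Among the measured compounds shown here, the single step between measured compounds, a step that the two limits leave unreadable from compound 1 to compound 2, therefore carries no readable size, and the one piece of evidence on it, (the limit of > 100000 nM in this assay, at which 2 of the 2 values shown sit), says only that both values sit at that limit.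

Compound 3 `COc1nc2ccc(CSc3ccc(C(=O)O)cn3)cc2nc1OC` differs from compound 2 by hydrogen in place of ethyl on an oxygen next to a carbonyl group. For the measured compounds named here, no measured step touches this place in the molecule, so nothing in the two values shown speaks for a change in either direction; the only guide is that compound 2 sits at the limit. The step from compound 2 to compound 3 is accordingly expected to be a step that the limit leaves unreadable from compound 2 to compound 3, no step beyond the scatter in this assay. Compound 3 is estimated to give 150000 nM, within a range from 50000 nM to 500000 nM, and the assay is expected most likely to report only a limit again.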

Compound 3, half-maximal cytotoxic concentration: 90000 nM
Compound 3: middle estimate off by 1.7-fold (0.22 log units), on the high side, and the stated range covers the measured number.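

In this assay compound 3 gives 90000 nM as a measured number. Compound 1 and compound 2 reached only a limit, so this position now has a step with a floor, not just an unreadable gap. Replacing ethyl with hydrogen on the oxygen next to a carbonyl group gives an at least 1.1-fold lower number from compound 2 to compound 3 (0.04 log units; that floor lies within the scatter) as the reading, and carboxy in place of hydrogen on an aromatic carbon gives an at least 1.1-fold lower number from compound 1 to compound 3 (0.04 log units; that floor lies within the scatter) as the reading, so neither step shows a change beyond the scatter. Going by these compounds, the true size of both steps stays unknown, since each one starts from a compound that has only a limit: (the limit of > 100000 nM in this assay, at which 2 of the 3 values shown sit).

On these data alone, it remains open whether an amide or an amine at this place would give a measured number in this assay or would stay at the limit, and whether such a number would lie clearly apart from that of compound 3. As far as these compounds go, a longer chain on the same oxygen, in place of ethyl, is equally open, as is how far such a change would move the reading from that of compound 2.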